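This account rests on a few compounds, and the source may have more. Where it says the series, first, only, none or still open, it means among the compounds named here.

For the measured compounds named here, compound 2 `O=C(/C=C/c1cccc(Cl)c1)c1ccc2ccccc2c1` stands as the higher of the two numbers so far in a functional assay on L1210 cells (Mus musculus) for cytotoxicity, read by MTT assay, with a stated time of 24 h, in the presence of a further agent that is not named here (a lower number here means a stronger inhibitor, a higher number a weaker inhibitor), where compound 2 gives 34000 nM; compound 1 `O=C(/C=C/c1cccc([N+](=O)[O-])c1)c1ccc2ccccc2c1` gives 20000 nM in this assay, and the gap is within the scatter. Compound 3 `O=C(/C=C/c1ccccc1)c1ccc2ccccc2c1` differs from compound 2 by hydrogen in place of chloro on an aromatic carbon. Going by the values given here, the only measured step bearing on this position is a 1.7-fold higher number from compound 1 to compound 2 (0.23 log units; within the scatter), which moved the number little. A step within the scatter in this assay is therefore expected, a 1.2-fold higher number from compound 2 to compound 3 (0.07 log units; within the scatter). For compound 3 the estimate in this assay is 40000 nM, expected to fall between 15000 nM and 100000 nM.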

Compound 3, half-maximal inhibitory concentration: 39000 nM
Estimate against measurement, compound 3: 1.0-fold (0.01 log units) above, and the stated range covers the measured number.
By their numbers in this assay, from the lowest: compounds 1, 2 and 3 (each within the scatter of the next).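

With hydrogen in place of chloro, the series gives a 1.1-fold higher number from compound 2 to compound 3 (0.06 log units; within the scatter), and with hydrogen in place of nitro it gives a 2.0-fold higher number from compound 1 to compound 3 (0.29 log units; within the scatter). The phenyl compound now provides a reference for this position, and in this assay neither chloro nor nitro separates from hydrogen there. All three compounds therefore stand level within the scatter, and no substituent at this place has yet shifted the number measurably.

Going by these compounds, whether an amine or a carboxylic acid on this aromatic carbon would move the number beyond the scatter remains open, as does the effect of any change to the shared core. No evidence is available to explain these close numbers.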